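The compounds below may be only part of what the source reports. "The series", "measured", "known", "first", "only" and "open" are said of these compounds alone.

Measured in a physicochemical assay for solubility, read by spectrophotometry, in phosphate buffer, with a stated time of 18 h, at pH 7.4; on this read-out lower numbers stand for lower solubility and higher numbers for higher solubility:
- compound 1 `CCc1ccc(-c2nc3c(c(C)nn3-c3ccccc3)c(-c3ccccc3S(C)(=O)=O)c2C#N)cc1`: 2200 nM
- compound 2 `CCc1ccc(-c2nc3c(c(C)nn3-c3ccccc3)c(-c3ccccc3C(=O)O)c2C#N)cc1`: 33000 nM
- compound 3 `CCc1ccc(-c2nc3c(c(C)nn3-c3ccccc3)c(-c3ccccc3OC)c2C#N)cc1`: 7800 nM

Compound 3 holds the second highest of the three numbers, with compound 1 its nearest neighbour and compound 2 its furthest. The next member is compound 4 `CCc1ccc(-c2nc3c(c(C)nn3-c3ccccc3)c(-c3ccc(O)cc3)c2C#N)cc1`, which has 4-hydroxyphenyl in place of 2-methoxyphenyl on an aromatic carbon, ortho to a cyano group and opposite the ring nitrogen: 4-hydroxyphenyl in place of 2-methoxyphenyl on an aromatic carbon.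

All three measured steps exchange a group on the aromatic ring at this same place. The largest is a 15-fold higher number from compound 1 to compound 2 (1.18 log units; beyond the scatter). The other two are modest: a 3.5-fold higher number from compound 1 to compound 3 (0.55 log units; beyond the scatter) and a 4.2-fold lower number from compound 2 to compound 3 (0.63 log units; beyond the scatter). All of them lie beyond the scatter, so changes on this ring can move the number. None of them, however, shows a hydroxy group or a group at another position on that ring, so they give neither direction nor size for the new change. No step beyond the scatter is therefore expected in this assay, although a modest step in either direction would not be surprising. The estimated change is a 1.2-fold higher number from compound 3 to compound 4 (0.06 log units; within the scatter). The expected value for compound 4 is 9000 nM, with an estimated range of 2500 nM to 30000 nM.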

Compound 4, solubility: 5700 nM
The estimate for compound 4 lay 1.6-fold (0.20 log units) above the measured number; low and high end bracket the measured number.
By their numbers in this assay, from the lowest: compound 1; then compounds 4 and 3 (each within the scatter of the next); then compound 2.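

In this assay, replacing 2-methoxyphenyl with 4-hydroxyphenyl on the aromatic carbon ortho to the cyano group gives a 1.4-fold lower number from compound 3 to compound 4 (0.14 log units; within the scatter), so this exchange, which alters both the oxygen-bearing group and its place on the ring, leaves the two compounds within the scatter of each other. The same 4-hydroxyphenyl group still stands apart from the other two groups at this place, with a 2.6-fold higher number from compound 1 to compound 4 (0.41 log units; beyond the scatter) and a 5.8-fold lower number from compound 2 to compound 4 (0.76 log units; beyond the scatter), so compound 4 falls with compound 3 in the range bounded by compound 1 and compound 2. No accompanying measurement accounts for any of these steps.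

Because hydroxy and methoxy differ here along with their places on the ring, the series does not show what either change does alone, and a 2-hydroxyphenyl or a 4-methoxyphenyl group at this place would separate the two. It also leaves open whether the large gap seen with the 2-carboxyphenyl group holds for a 4-carboxyphenyl group, and how a basic amine such as 4-aminophenyl or a longer chain such as 4-(2-hydroxyethyl)phenyl would stand.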